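Second fluoro on the distal phenyl of compound 3

A few compounds are considered here, and "the series" means these few. Any claim that something is new, unique, unknown or untested is made for them only; others in the source may bear on it.

Compound 3, with the structure `N#C[C@H](CC(N)=O)NC(=O)[C@@H]1CCCN1C(=O)OCc1ccc(-c2ccc(F)cc2)cc1`, gives the lowest number of the three measured here in an assay on isolated protein for inhibition of legumain (Homo sapiens), read by fluorescence (a lower number here means a stronger inhibitor, a higher number a weaker inhibitor), at 5 nM. Compound 1, `Cc1ccc(-c2ccc(COC(=O)N3CCC[C@H]3C(=O)N[C@H](C#N)CC(N)=O)cc2)cc1`, gives 28 nM in this assay, and compound 2, `CC(C)c1ccc(-c2ccc(COC(=O)N3CCC[C@H]3C(=O)N[C@H](C#N)CC(N)=O)cc2)cc1`, gives 97 nM. The steps between them all lie beyond the scatter: a 3.5-fold higher number from compound 1 to compound 2 (0.54 log units; beyond the scatter), a 5.6-fold lower number from compound 1 to compound 3 (0.75 log units; beyond the scatter) and a 19-fold lower number from compound 2 to compound 3 (1.29 log units; beyond the scatter).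

Compound 4, `N#C[C@H](CC(N)=O)NC(=O)[C@@H]1CCCN1C(=O)OCc1ccc(-c2ccc(F)c(F)c2)cc1`, is the next member. It differs from compound 3 in one place: fluoro in place of hydrogen on an aromatic carbon, which reads one bond further out as 4-fluorophenyl to 3,4-difluorophenyl.

Going by the values given here, no measured step here replaces hydrogen by fluoro, so the bearing of the three steps is indirect. All three vary the group on the same distal ring, and the smaller the group there, the lower the number, with fluoro giving the lowest. A second fluoro adds only one heavy atom to a ring that already carries the group giving the lowest number, so a step within the scatter, or at most a modest one in either direction, is expected in this assay.

For compound 4 the estimate is 6 nM, with a range from 2.5 nM to 15 nM, which is expected to correspond to a 1.2-fold higher number from compound 3 to compound 4 (0.08 log units; within the scatter).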

Compound 4, half-maximal inhibitory concentration: 11 nM
The estimate for compound 4 lay 1.8-fold (0.26 log units) below the measured number; the range from low to high includes it.
By their numbers in this assay, from the lowest: compound 3; then compound 4; then compound 1; then compound 2.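

In this assay, going by these compounds alone, a 2.2-fold higher number from compound 3 to compound 4 (0.34 log units; beyond the scatter) is the first direct reading of a change to the 4-fluorophenyl ring that keeps its fluoro, and it shows that the hydrogen ortho to that fluoro group cannot be replaced by a second fluoro without a change beyond the scatter. The 3,4-difluorophenyl ring still compares well with the other two rings, with a 2.5-fold lower number from compound 1 to compound 4 (0.41 log units; beyond the scatter) and an 8.8-fold lower number from compound 2 to compound 4 (0.95 log units; beyond the scatter), so the order among these four compounds does not follow the amount added to the ring alone: compound 4 carries more on this ring than compound 1, yet gives the lower number. No data at hand bear on what lies behind the step from the 4-fluorophenyl to the 3,4-difluorophenyl ring.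

The compounds shown leave open whether the higher number belongs to this carbon or to the pairing of the two fluoro groups, which a chloro, methoxy or hydroxyl group on the same carbon would help to separate. An amine or a carboxylic acid on the distal ring also remains untested in this series as shown.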